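A few compounds are considered here, and "the series" means these few. Any claim that something is new, unique, unknown or untested is made for them only; others in the source may bear on it.

Working notes on the series.

Among the measured compounds shown here, compound 1 `COc1cc(-c2cc(/C=C/C(=O)c3ccc(Cl)c(Cl)c3)[nH]n2)cc(OC)c1OC` is the weakest of the three measured members in a functional assay on BT-549 cells (Homo sapiens) for inhibition, read by sulforhodamine B assay, with a stated time of 48 h; on this read-out lower numbers stand for stronger inhibition of growth and higher numbers for weaker inhibition of growth: compound 1 gives 29300 nM. Compound 2 `COc1ccc(-c2cc(/C=C/C(=O)c3ccc(N)cc3)[nH]n2)cc1OC` gives 2940 nM and compound 3 `COc1ccc(-c2cc(/C=C/C(=O)c3cc(OC)c(OC)c(OC)c3)[nH]n2)cc1OC` gives 2930 nM; both lie well beyond the scatter from compound 1, while compound 2 and compound 3 sit within the scatter of each other, so no order can be set between them.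

Compound 4 `COc1ccc(C(=O)/C=C/c2cc(-c3cc(OC)c(OC)c(OC)c3)n[nH]2)cc1OC` is not yet measured. Relative to compound 1 it carries 3,4-dimethoxyphenyl in place of 3,4-dichlorophenyl on a carbonyl carbon. For the measured compounds named here, no direct step between measured compounds covers this change, so the expectation rests on the wider picture: compound 2 and compound 3, which carry an aryl group other than the 3,4-dichlorophenyl on the carbonyl carbon, both give much lower numbers than compound 1. On that basis a large step toward lower numbers is expected, a 7.3-fold lower number from compound 1 to compound 4 (0.86 log units; beyond the scatter), in this assay. Compound 4 is therefore expected to give 4000 nM, within a range of 1200 nM to 14000 nM.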

Compound 4, concentration for total growth inhibition: 2900 nM
For compound 4 the middle estimate is 1.4-fold (0.14 log units) above the measured one, within the range that was stated.
By their numbers in this assay, from the lowest: compounds 4, 3 and 2 (each within the scatter of the next); then compound 1.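

Among the compounds shown here, on the carbonyl carbon, 3,4-dimethoxyphenyl in place of 3,4-dichlorophenyl gives the first direct reading of a change at this position: in this assay the exchange gives a 10-fold lower number from compound 1 to compound 4 (1.00 log units; beyond the scatter), with the rest of the core of compound 1 unchanged. For the compounds shown here, the aryl group on the carbonyl carbon alone is thus enough to carry a step beyond the scatter, which the earlier compounds, none differing from another in one place, could not show. No measurement at hand accounts for the size of this step.

Open, going by these compounds, is whether a 4-methoxyphenyl, with one methoxy group, or a phenyl bearing a carboxylic acid or an amine at this carbonyl carbon would hold the lower number. Also open, on these data alone, is whether the same exchange gives a similar step when the other aryl group on the shared core is different.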